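The source may hold more compounds than are shown below. What is called first, only, known or untested is meant among the compounds shown, and "the series" means these compounds.

Compound 1 `O=C(CCSc1ccc2c(/C=C/c3ccccn3)n[nH]c2c1)Nc1cccc(F)c1`: 6590 nM
Compound 2 `O=C(CCSc1ccc2c(/C=C/c3ccccn3)n[nH]c2c1)NCc1cccc(C(F)(F)F)c1`: 8030 nM
Compound 3 `O=C(CCSc1ccc2c(/C=C/c3ccccn3)n[nH]c2c1)Nc1ccc(F)c(C(F)(F)F)c1`: 610 nM

All three compounds were tested in an ADME assay on BaF3 cells (Mus musculus) for antiproliferative activity, read by CCK-8 assay, with a stated time of 72 h; a lower number here means a stronger inhibitor of growth, a higher number a weaker inhibitor of growth. Compound 3, at 610 nM, has the lowest number of the three, and its gaps to both others lie beyond the scatter. Compound 4 `Cc1ccc(NC(=O)CCSc2ccc3c(/C=C/c4ccccn4)n[nH]c3c2)cc1C(F)(F)F` differs from compound 3 in a single place: methyl in place of fluoro on an aromatic carbon. This is methyl in place of fluoro on an aromatic carbon, ortho to a trifluoromethyl group.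

Among the compounds with values here, no measured step makes this exchange on its own. The nearest evidence is the large step of an 11-fold lower number from compound 1 to compound 3 (1.03 log units; beyond the scatter) and the large step of a 13-fold lower number from compound 2 to compound 3 (1.12 log units; beyond the scatter), but each replaces the whole group on the amide-type nitrogen. The step of a 1.2-fold higher number from compound 1 to compound 2 (0.09 log units; within the scatter) stays within the scatter. These steps give no direction for the exchange, and the 3-(trifluoromethyl) group remains in place, so no step beyond the scatter is expected. The expected step is a 1.3-fold higher number from compound 3 to compound 4 (0.12 log units; within the scatter), a small one. For compound 4 the estimated value is 800 nM, within an expected range of 250 nM to 2500 nM.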

Compound 4, concentration for 50% growth inhibition: 530 nM
Beside the measured number, compound 4's estimate is 1.5-fold (0.18 log units) above it, within the range that was stated.
By their numbers in this assay, from the lowest: compounds 4 and 3 (each within the scatter of the next); then compounds 1 and 2 (each within the scatter of the next).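

In this assay the exchange of fluoro for methyl, at a place ortho to a trifluoromethyl group and para to a large group, gives a 1.2-fold lower number from compound 3 to compound 4 (0.06 log units; within the scatter) and so leaves the number unchanged within the scatter. The large distance to the earlier compounds is kept with methyl at this place, as shown by a 15-fold lower number from compound 2 to compound 4 (1.18 log units; beyond the scatter) and by a 12-fold lower number from compound 1 to compound 4 (1.09 log units; beyond the scatter) in the same assay, so it is not tied to fluoro alone. Nothing measured here bears on the reason for this.

Compounds 3 and 4 leave open what plain hydrogen at this place would give, and so whether the place needs a substituent at all. They also leave open how an amine, a carboxylic acid or a methoxy group would fare there, and whether either result holds without the trifluoromethyl group.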